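Trading the Methoxyphenyl Arm for a Chlorophenyl

This account rests on a few compounds, and the source may have more. Where it says the series, first, only, none or still open, it means among the compounds named here.

Of the compounds shown here, two built on one shared core have been measured in a functional assay on MOLT-4 cells (Homo sapiens) for antiproliferative activity; a higher number here means a weaker inhibitor, a lower number a stronger inhibitor. Compound 1 `CCOc1ccc(-c2cc(N)c(C(=O)c3cc(OC)c(OC)c(OC)c3)s2)cc1` gives 240 nM. Compound 2 `COc1ccc(-c2cc(N)c(C(=O)c3cc(OC)c(OC)c(OC)c3)s2)cc1` gives 18 nM, the lowest of the two numbers, so it is the stronger inhibitor of the pair. Going by the values given here, the single measured step, a 13-fold lower number from compound 1 to compound 2 (1.12 log units; beyond the scatter), was large.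

Compound 3 `COc1cc(C(=O)c2sc(-c3ccccc3Cl)cc2N)cc(OC)c1OC` differs from compound 2 in one place: 2-chlorophenyl in place of 4-methoxyphenyl on an aromatic carbon. Among the compounds with values here, no measured step covers an exchange of this kind. Within the data shown here, the only step available concerns the chain on the oxygen of the very arm that now leaves, and it was large, so the outcome here is open and a wide range is needed, with a weaker result somewhat more likely than a stronger one. Compound 3 is expected to give 100 nM, within a range of 15 nM to 800 nM. That estimate amounts to a 5.6-fold higher number from compound 2 to compound 3 (0.74 log units; beyond the scatter).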

Compound 3, half-maximal inhibitory concentration: 17 nM
Beside the measured number, compound 3's estimate is 5.9-fold (0.77 log units) above it; measured number inside the range.
By their numbers in this assay, from the lowest: compounds 3 and 2 (each within the scatter of the next); then compound 1.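

In this assay, the arm on the aromatic carbon next to the ring sulfur can be exchanged outright with no shift beyond the scatter: the change gives a 1.1-fold lower number from compound 2 to compound 3 (0.02 log units; within the scatter). Compound 3 carries 2-chlorophenyl, an arm with no oxygen and no hydrogen-bond acceptor, so an oxygen on this arm is not needed for a number as low as that of compound 2, and the large gap seen with 4-ethoxyphenyl returns here as a 14-fold lower number from compound 1 to compound 3 (1.15 log units; beyond the scatter). Nothing measured explains why the two arms give matching numbers.

From the compounds shown here alone, what the chlorine itself contributes stays open, and plain phenyl or 2-fluorophenyl at this place would help to settle it. Also open, going by these compounds, is how far the arm can depart from a carbon-only ring, for instance to a pyridine ring.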